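Benzylsulfanyl variation on the shared core

This account rests on a few compounds, and the source may have more. Where it says the series, first, only, none or still open, it means among the compounds named here.

Among the measured compounds shown here, compound 1 `COc1ccc(CSc2nc3nc(C)cc(Nc4ccc(C(=O)/C=C/c5ccc6ccccc6c5)cc4)n3n2)cc1` gives the lowest of the three numbers so far in a functional assay on SW-620 cells (Homo sapiens) for cytotoxicity, read by MTT assay, with stated times of 4 h and 72 h, tested at 5 uM (a higher number here means a weaker inhibitor, a lower number a stronger inhibitor), at 250 nM. Compound 2 `Cc1cc(Nc2ccc(C(=O)/C=C/c3ccc4ccccc4c3)cc2)n2nc(SCc3ccc(Br)cc3)nc2n1` gives 370 nM, a change of a 1.5-fold higher number from compound 1 to compound 2 (0.17 log units; within the scatter) and so not separable from compound 1. Compound 3 `Cc1cc(Nc2ccc(C(=O)/C=C/c3ccc4ccccc4c3)cc2)n2nc(SCc3ccccc3[N+](=O)[O-])nc2n1` gives 960 nM, a change of a 3.8-fold higher number from compound 1 to compound 3 (0.58 log units; beyond the scatter) that sets it apart from compound 1; compound 3 also sits apart from compound 2 by a 2.6-fold higher number from compound 2 to compound 3 (0.41 log units; beyond the scatter). Compound 4 `Cc1cc(Nc2ccc(C(=O)/C=C/c3ccc4ccccc4c3)cc2)n2nc(SCc3cccc([N+](=O)[O-])c3)nc2n1` differs from compound 1 by 3-nitrophenyl in place of 4-methoxyphenyl on a saturated chain carbon bound to a sulfur. The two steps toward compound 3 bear on this, both modest and both toward higher numbers, though the entering ring now stands as 3-nitrophenyl rather than 2-nitrophenyl. A modest rise is therefore expected for compound 4, of about a 2.6-fold higher number from compound 1 to compound 4 (0.41 log units; beyond the scatter). Compound 4 is estimated at 650 nM, with a range of 300 nM to 1400 nM.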

Compound 4, half-maximal inhibitory concentration: 790 nM
Compound 4: the middle estimate sits 1.2-fold (0.08 log units) below what was measured; the range from low to high includes it.
By their numbers in this assay, from the lowest: compounds 1 and 2 (each within the scatter of the next); then compounds 4 and 3 (each within the scatter of the next).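

In this assay, 3-nitrophenyl and 2-nitrophenyl cannot be separated at this position, with a 1.2-fold lower number from compound 3 to compound 4 (0.08 log units; within the scatter). The second nitrophenyl compound also stands apart from the 4-methoxyphenyl and 4-bromophenyl compounds, with a 3.2-fold higher number from compound 1 to compound 4 (0.50 log units; beyond the scatter) and a 2.1-fold higher number from compound 2 to compound 4 (0.33 log units; beyond the scatter), so the higher numbers are no longer tied to 2-nitrophenyl alone. Nothing measured on these groups speaks to what lies behind these steps. Still open, going by these compounds, is how 4-nitrophenyl, an amine or a carboxylic acid on the ring, or a longer chain in place of the benzyl carbon would read in this assay.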